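This account rests on a few compounds, and the source may have more. Where it says the series, first, only, none or still open, it means among the compounds named here.

Measured so far:
- compound 1 `COc1ccc(-c2coc3cc(OCCCSC(=S)N4CCN(Cc5ccccc5)CC4)ccc3c2=O)cc1`: 14900 nM
- compound 2 `COc1ccc(-c2coc3cc(OCCCCSC(=S)N4CCN(C(=O)OC(C)(C)C)CC4)ccc3c2=O)cc1`: 4610 nM
- compound 3 `COc1ccc(-c2coc3cc(OCCSC(=S)N4CCN(C(=O)OC(C)(C)C)CC4)ccc3c2=O)cc1`: 3640 nM

In a functional assay on PC-3 cells (Homo sapiens) for inhibition, read by MTT assay, with a stated time of 48 h (a lower number here means a stronger inhibitor, a higher number a weaker inhibitor), compound 1 gives 14900 nM, the highest of the three numbers; compound 2 and compound 3, both carrying a tert-butoxycarbonyl group on the ring nitrogen, sit lower by margins beyond the scatter. Compound 4 `COc1ccc(-c2coc3cc(OCCCSC(=S)N4CCN(C(C)=O)CC4)ccc3c2=O)cc1` is not yet measured. It differs from compound 1 as follows: acetyl in place of benzyl on an amine nitrogen in a ring. For the measured compounds named here, no measured step isolates this change. Since both compounds with a carbonyl-bearing group on that nitrogen sit below compound 1, a lowering of the number is expected, of moderate size, a 2.0-fold lower number from compound 1 to compound 4 (0.30 log units; within the scatter). Compound 4 is estimated at 7500 nM, within 3000 nM to 20000 nM.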

Compound 4, half-maximal inhibitory concentration: 4310 nM
Estimate against measurement, compound 4: 1.7-fold (0.24 log units) above; low and high end bracket the measured number.
By their numbers in this assay, from the lowest: compounds 3, 4 and 2 (each within the scatter of the next); then compound 1.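

In this assay, for the compounds shown here, acetyl in place of benzyl on the amine nitrogen in the ring gives a 3.5-fold lower number from compound 1 to compound 4 (0.54 log units; beyond the scatter), the first single-change reading at this position. The benzyl ring is therefore not needed there to keep the number low, at least in this one pair. The step changes the ring and the carbonyl together, and no measurement available explains it.

A benzoyl group on that nitrogen, keeping the ring and adding a carbonyl, would separate those two parts of the change. Also open, going by these compounds, is how tert-butoxycarbonyl reads on the chain of compound 4.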